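The source may report more compounds than this note shows. Statements on the series, on what has been measured and on what is new or still open speak of the compounds shown alone.

Working notes on the series. The shared core of compound 1, `O=C1C[C@H](O)CC(CCc2ccccc2-c2ccccc2)O1`, is carried through all four compounds. In an assay for inhibition of 3-hydroxy-3-methylglutaryl-coenzyme A reductase (Rattus norvegicus) (a lower number here means a stronger inhibitor, a higher number a weaker inhibitor), compound 1 gives 44000 nM. Compound 2, `O=C1C[C@H](O)CC(CCc2c(Cl)cc(Cl)cc2-c2ccccc2)O1`, gives 100 nM in this assay. Among the measured compounds shown here, compound 3, `COc1ccc(-c2cc(Cl)cc(Cl)c2/C=C/[C@@H]2C[C@@H](O)CC(=O)O2)cc1`, gives 470 nM in this assay and stands second highest of the three numbers so far, nearer to compound 2 than to compound 1, with both gaps beyond the scatter. Compound 2 and compound 3 differ in two places, so their values are set side by side only as two readings, without a single change to credit.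

The step to compound 4, `O=C1C[C@H](O)C[C@@H](/C=C/c2c(Cl)cc(Cl)cc2-c2ccccc2)O1`, is one change: hydrogen in place of methoxy on an aromatic carbon. For the measured compounds named here, no pair of measured compounds shows this change alone, so the step is judged from the neighbourhood of compound 3 and compound 2 in this assay. The expectation is for a small move downward from compound 3 to compound 4, a 1.6-fold lower number from compound 3 to compound 4 (0.19 log units; within the scatter), not clearly beyond the scatter. For compound 4 the estimate in this assay is 300 nM, within a range of 100 nM to 900 nM.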

Compound 4, half-maximal inhibitory concentration: 80 nM
Compound 4: middle estimate off by 3.8-fold (0.57 log units), on the high side, and the stated range ends above it.
By their numbers in this assay, from the lowest: compounds 4 and 2 (each within the scatter of the next); then compound 3; then compound 1.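

In this assay, among the compounds shown here, the change from 4-methoxyphenyl to phenyl gives a 5.9-fold lower number from compound 3 to compound 4 (0.77 log units; beyond the scatter) and is the first single-change step. It shows that, on this aromatic carbon para to a large group, the methoxy compound carries the higher number and that the gap between this pair lies beyond the scatter. Nothing on hand bears on why the number moves at this position.

For the compounds shown here, what an amine, a carboxylic acid, a hydroxyl or a fluorine on the same carbon would give remains open, since hydrogen and methoxy are the only two groups compared here. Also open, on these data alone, is whether the change from 4-methoxyphenyl to phenyl would read the same on the structure of compound 2, which differs from compound 4 elsewhere.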